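Working notes on the step from compound 3 to compound 4

The compounds below may be only part of what the source reports. "The series", "measured", "known", "first", "only" and "open" are said of these compounds alone.

Compound 1 `CCO[C@H]1C[C@@H](c2coc3ccc(Br)cc3c2=O)N(c2ccccc2)O1` — > 60000 nM, a limit of the assay.
Compound 2 `Cc1ccc2occ([C@@H]3C[C@H](c4ccccc4)ON3c3ccccc3)c(=O)c2c1` — > 60000 nM, a limit of the assay.
Compound 3 `CCO[C@H]1C[C@@H](c2coc3ccccc3c2=O)N(c2ccccc2)O1` — > 60000 nM, a limit of the assay.

In a functional assay on PC-3 cells (Homo sapiens) for inhibition, read by sulforhodamine B assay, with a stated time of 48 h (a higher number here means a weaker inhibitor, a lower number a stronger inhibitor), compound 1 gives > 60000 nM, which is a limit and not a number. In this assay compound 2 gives > 60000 nM, again only a limit. In this assay compound 3 gives > 60000 nM, also only a limit. Compound 3 therefore stands where every measured compound stands: at the limit, with no number that would set it apart from compound 1 or compound 2. Going by the values given here, the one measured step between neighbours, a step that the two limits leave unreadable from compound 1 to compound 3, cannot be read because of the limit of > 60000 nM in this assay, at which 3 of the 3 values shown sit.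

Compound 4 `CCO[C@H]1C[C@@H](c2coc3ccc(C)cc3c2=O)N(c2ccccc2)O1` differs from compound 3 by methyl in place of hydrogen on an aromatic carbon. Among the compounds with values here, no measured step bears on this particular change, and the only step available, from compound 1 to compound 3, gives no size at all. Nothing in the numbers suggests that the change would move the series away from the limit. The step that the limit leaves unreadable from compound 3 to compound 4 is therefore expected to be nothing beyond the scatter. Compound 4 is estimated at 80000 nM, with a range from 30000 nM to 250000 nM, and most likely the assay will again report only a limit.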

Compound 4, half-maximal inhibitory concentration: 39000 nM
Compound 4: the middle estimate sits 2.1-fold (0.31 log units) above what was measured; low and high end bracket the measured number.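

Methyl on this aromatic carbon gives the first actual number in the series rather than a limit in this assay. Set against hydrogen, the change gives an at least 1.5-fold lower number from compound 3 to compound 4 (0.18 log units; that floor lies within the scatter), and with bromo as the group replaced, the reading is an at least 1.5-fold lower number from compound 1 to compound 4 (0.18 log units; that floor lies within the scatter). With ethoxy in place of phenyl on a saturated ring carbon, the reading is an at least 1.5-fold lower number from compound 2 to compound 4 (0.18 log units; that floor lies within the scatter), and all three readings are floors rather than sizes because the other compounds give no number: the limit of > 60000 nM in this assay, at which 3 of the 4 values shown sit.

The compounds shown leave open whether compound 4 truly stands apart from the compounds at the limit by more than the scatter, so methyl cannot yet be said to matter at this position. Also open, on these data alone, is what a longer chain such as propyl, a methoxy group or an amine on this aromatic carbon would give in this assay.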